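Chloro to trifluoromethyl on the shared core

The compounds below may be only part of what the source reports. "The series", "measured", "known", "first", "only" and "open" are said of these compounds alone.

Measured compounds:
compound 1 `O=C(/C=C/c1ccc2c(c1)B(O)OC2)c1ccc(Cl)cc1` 7900 nM
compound 2 `O=C(/C=C/c1ccc2c(c1)B(O)OC2)c1ccc(OCc2ccccc2)cc1` 5300 nM

Within the data shown here, in a functional assay on MDA-MB-231 cells (Homo sapiens) for cytotoxicity, read by MTT assay, with a stated time of 48 h (a higher number here means a weaker inhibitor, a lower number a stronger inhibitor), compound 1 stands highest of the two numbers, and its one neighbour is compound 2, reached by a 1.5-fold lower number from compound 1 to compound 2 (0.17 log units; within the scatter), a change within the scatter.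

Compound 3 `O=C(/C=C/c1ccc2c(c1)B(O)OC2)c1ccc(C(F)(F)F)cc1` differs from compound 1 in one place: trifluoromethyl in place of chloro on an aromatic carbon. Among the measured compounds shown here, the only measured step, from chloro to benzyloxy at this carbon, stayed within the scatter, and nothing measured speaks to trifluoromethyl itself. No step beyond the scatter is therefore expected for compound 3, that is a 1.1-fold lower number from compound 1 to compound 3 (0.05 log units; within the scatter). Compound 3 is estimated at 7000 nM, with a range of 3000 nM to 16000 nM.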

Compound 3, half-maximal inhibitory concentration: 9200 nM
The estimate for compound 3 lay 1.3-fold (0.12 log units) below the measured number; the range from low to high includes it.
By their numbers in this assay, from the lowest: compounds 2, 1 and 3 (each within the scatter of the next).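

In this assay, trifluoromethyl on this aromatic carbon gives a 1.2-fold higher number from compound 1 to compound 3 (0.07 log units; within the scatter) and a 1.7-fold higher number from compound 2 to compound 3 (0.24 log units; within the scatter). Chloro, benzyloxy and trifluoromethyl, para to a large group, therefore all lie within the scatter of one another, and this read-out does not separate them. No evidence on the cause of this result is available. On these data alone, it remains open whether an amine or a carboxylic acid on this carbon would give a step beyond the scatter. Changes elsewhere on the shared core also remain open.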